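Removing the para-chloro from a chalcone-type antiproliferative series

The source may hold more compounds than are shown below. What is called first, only, known or untested is meant among the compounds shown, and "the series" means these compounds.

Measured so far:
- compound 1, `COc1ccc(-c2cc(/C=C/C(=O)c3ccccc3)nc3cc(-c4ccccc4)nn23)cc1OC` — 10700 nM
- compound 2, `COc1cc(-c2cc(/C=C/C(=O)c3ccc(Cl)cc3)nc3cc(-c4ccccc4)nn23)cc(OC)c1OC` — 15500 nM

Of the compounds shown here, two have been tested in a functional assay on A549 cells (Homo sapiens) for antiproliferative activity, read by MTT assay, with a stated time of 24 h; on this read-out lower numbers stand for stronger inhibition and higher numbers for weaker inhibition. Compound 1 gives 10700 nM and compound 2 gives 15500 nM. On these two numbers compound 2 stands highest, but the gap to compound 1 is within the scatter, so the two cannot be placed in any order. The two compounds also differ in more than one place, so nothing can be read from them about any single change.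

Compound 3, `COc1cc(-c2cc(/C=C/C(=O)c3ccccc3)nc3cc(-c4ccccc4)nn23)cc(OC)c1OC`, has not yet been measured. It differs from compound 2 in one place: hydrogen in place of chloro on an aromatic carbon. For the measured compounds named here, no pair of measured compounds shows what this change does here. With nothing to point one way or the other, the author expects the step from compound 2 to compound 3 in this assay to be small, in either direction, and not beyond the scatter. The estimate for compound 3 in this assay is 13000 nM, with a range from 6000 nM to 30000 nM, which means an expected step of a 1.2-fold lower number from compound 2 to compound 3 (0.08 log units; within the scatter).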

Compound 3, half-maximal inhibitory concentration: 18200 nM
Compound 3: the middle estimate sits 1.4-fold (0.15 log units) below what was measured; measured number inside the range.
By their numbers in this assay, from the lowest: compounds 1, 2 and 3 (each within the scatter of the next).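

Hydrogen in place of chloro on an aromatic carbon, para to a large group, gives a 1.2-fold higher number from compound 2 to compound 3 (0.07 log units; within the scatter) in this assay, the first reading of a change at this position, and the 4-chlorophenyl and phenyl compounds cannot be told apart on it. Methoxy in place of hydrogen on an aromatic carbon gives a 1.7-fold higher number from compound 1 to compound 3 (0.23 log units; within the scatter), so the other single change among these compounds also stays inside the scatter. For the compounds shown here, the three compounds therefore cannot be put in any order, and neither change can be said to matter for this read-out on the numbers so far. No outside measurement bears on these two steps.

The compounds shown leave open whether an amine or a carboxylic acid in place of the chloro on this ring would give a step beyond the scatter, since chloro and hydrogen are the only two groups seen here. They also leave open whether hydrogen in place of chloro would read the same way on the core of compound 1, which carries one methoxy fewer.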